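This account rests on a few compounds, and the source may have more. Where it says the series, first, only, none or still open, it means among the compounds named here.

Measured in an ADME assay on HEK293 cells (Homo sapiens) for cytotoxicity, with a stated time of 72 h; on this read-out higher numbers stand for an effect only at larger amounts of compound and lower numbers for an effect already at smaller amounts:
- compound 1 `O=C(Nc1ccc(O)c(-c2nc3ccccc3s2)c1)c1cc([N+](=O)[O-])ccc1Cl`: > 25000 nM
- compound 2 `O=C(Nc1nc(-c2cccc(F)c2)cs1)c1cc([N+](=O)[O-])ccc1Cl`: 8700 nM
- compound 3 `O=C(Nc1nc2ccc(F)cc2s1)c1cc([N+](=O)[O-])ccc1Cl`: > 27000 nM

Compound 1 does not give a number in this assay; its value is a limit of the assay, > 25000 nM. Compound 3 also stops at a limit, > 27000 nM. Only compound 2 returns a measured value, 8700 nM. On the numbers shown, compound 1 therefore stands at the upper edge of what this assay reports, and one further value shown is a limit as well: the limit of > 25000 nM in this assay, at which 1 of the 3 values shown sits, and (the limit of > 27000 nM in this assay, at which 1 of the 3 values shown sits).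

Compound 4 `COc1ccc(NC(=O)c2cc([N+](=O)[O-])ccc2Cl)cc1-c1nc2ccccc2s1` is the next compound to be measured. It differs from compound 1 in a single place: methyl in place of hydrogen on an oxygen on an aromatic ring. Among the measured compounds shown here, no step between two measured compounds is available, so there is no measured pair to calibrate this change against. Given the limit seen for compound 1, the expected effect of the change in this assay is none beyond the usual scatter, with a fair chance that compound 4 again returns only a limit rather than a number. Compound 4 is expected to come in around 25000 nM in this assay. The range for compound 4 is estimated as 9000 nM to 60000 nM. The step of a number no higher from compound 1 to compound 4 (the limit leaves the size open) is expected to lie within the scatter.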

Compound 4, half-maximal effective concentration: > 25000 nM
Compound 4: no number, only a limit; the forecaster's own chance of this, stated with the estimate: 60%; the middle value sits exactly at the limit.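

In this assay, compound 1 and compound 4 both return only a limit of the assay, so no step can be read for the change from hydroxy to methoxy. The compounds shown leave open where the true values of compound 1 and compound 4 lie, and whether this change has any effect on the read-out.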